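Triazole hydroxamates against HDAC6: one ring swap

The compounds below may be only part of what the source reports. "The series", "measured", "known", "first", "only" and "open" are said of these compounds alone.

Measured so far:
compound 1 `O=C(NO)c1ccc(NCc2nc(-c3cccc4cnccc34)nn2-c2ccccc2)cc1`: 40.2%
compound 2 `O=C(NO)c1ccc(NCc2nc(-c3ccccc3)nn2-c2ccccc2Cl)cc1`: 64.6%

In an assay on Sf9 cells for inhibition of protein deacetylase HDAC6 (Homo sapiens), read by fluorescence, with a stated time of 40 min, tested at 100 nM (on this read-out higher numbers stand for more inhibition at the one concentration tested (going by the name of the read-out) and lower numbers for less inhibition), compound 1 gives 40.2%, the lower of the two numbers shown; compound 2 gives 64.6%, beyond the scatter above it. Going by the values given here, no pair differing in one place has been measured, so no step size is known.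

Compound 3 `O=C(NO)c1ccc(NCc2nc(-c3ccncc3)nn2-c2ccccc2)cc1` differs from compound 1 by pyridin-4-yl in place of isoquinolin-5-yl on an aromatic carbon. Nothing measured here speaks to this change, so the expected step from a number 4.8 percentage points higher from compound 1 to compound 3 (within the scatter) is small, likely within the scatter, in either direction. For compound 3 the estimate is 45%, with a range from 25% to 65%.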

Compound 3, a percentage reported as inhibition, at one concentration (the size of the read-out at that concentration, not a potency): 30.8%
Estimate against measurement, compound 3: 14.2 percentage points above; the measured number falls inside the stated range.
By their numbers in this assay, from the lowest: compounds 3 and 1 (each within the scatter of the next); then compound 2.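

On the aromatic carbon of the five-membered ring, pyridin-4-yl in place of isoquinolin-5-yl gives a number 9.4 percentage points lower from compound 1 to compound 3 (within the scatter) in this assay. The carbon-only six-membered ring of isoquinolin-5-yl can therefore go without a step beyond the scatter, at least for this pair. No measurement bears on why the two compounds read alike.

Open, as far as these compounds go, is how this read-out responds to a non-aromatic group on this carbon, such as an amine or a carboxylic acid. Compound 2 differs from compound 1 and compound 3 in more than one place, so it cannot settle this.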